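This account rests on a few compounds, and the source may have more. Where it says the series, first, only, none or still open, it means among the compounds named here.

Of the compounds shown here, three have been measured in a functional assay on SNB-75 cells (Homo sapiens) for cytotoxicity, read by sulforhodamine B assay, with a stated time of 48 h; on this read-out higher numbers stand for weaker inhibition of growth and lower numbers for stronger inhibition of growth. Compound 1 `ClCc1ccccc1Cn1cnc2c(Cl)nc(Cl)nc21` gives 1540 nM, compound 2 `ClCc1ccccc1Cn1cnc2c(Cl)ncnc21` gives 2880 nM, and compound 3 `ClCc1cccc(Cn2cnc3ncnc(Cl)c32)c1` gives 1860 nM. Compound 1 differs from compound 2 in one place, (chloro in place of hydrogen on an aromatic carbon), and this change brought a 1.9-fold lower number from compound 2 to compound 1 (0.27 log units; within the scatter). Compound 3 is built from the same atoms as compound 2, joined differently; the difference between the two cores is not broken down here, and the values of compound 2 and compound 3 in this assay lie within the scatter of each other, as do those of compound 3 and compound 1.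

Compound 4 `ClCc1cccc(Cn2cnc3nc(Cl)nc(Cl)c32)c1` has not yet been measured. It differs from compound 3 by chloro in place of hydrogen on an aromatic carbon, which is the same change that separates compound 2 from compound 1, at a place described in the same words. Because that change gave a 1.9-fold lower number from compound 2 to compound 1 (0.27 log units; within the scatter), a step of like size is expected from it here, a 1.9-fold lower number from compound 3 to compound 4 (0.27 log units; within the scatter), with the caution that a step of this size remains within the usual scatter. On that basis compound 4 is expected to give about 1000 nM in this assay, most likely between 500 nM and 2200 nM.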

Compound 4, concentration for 50% growth inhibition: 1090 nM
Compound 4: the middle estimate sits 1.1-fold (0.04 log units) below what was measured; the measured number falls inside the stated range.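

In this assay, chloro in place of hydrogen on an aromatic carbon brought a 1.7-fold lower number from compound 3 to compound 4 (0.23 log units; within the scatter), and this step can be set beside the one on the other core: the same change on two cores in this assay, a 1.9-fold lower number (0.27 log units; within the scatter) from compound 2 to compound 1 and a 1.7-fold lower number (0.23 log units; within the scatter) from compound 3 to compound 4, 1.1-fold (0.04 log units) apart, within the scatter of two such steps. The change therefore carried from one core to the other with a step of like size, and on these two cores its size did not depend on which core bore it. This does not show that the change itself strengthens growth inhibition, as each step taken alone remains within the scatter, and two cores are too few to support a rule for the whole series.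

The compounds shown carry only hydrogen or chloro at this place, so it remains open whether an amine, a methoxy group or a longer chain there would give a step that clearly exceeds the scatter. Also open, on these data alone, is whether the same step would hold on a third core or in other cell lines.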